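This account rests on a few compounds, and the source may have more. Where it says the series, first, only, none or still open, it means among the compounds named here.

Compound 1 `COc1ccc(C[S+]([O-])c2ncccc2C(=O)Nc2ccncc2)c(OCCF)c1` gives < 0.02 h
Compound 2 `COc1cc(C)c(C[S+]([O-])c2ncccc2C(=O)Nc2ccncc2)c(OC)c1` gives < 0.02 h

In an ADME assay (a higher number here means that the compound lasts longer, a lower number that the compound disappears faster), compound 1 gives < 0.02 h as a limit of the assay, not a number. Compound 2 gives < 0.02 h as a limit too. Both compounds sit at the same limit (the limit of < 0.02 h in this assay, at which 2 of the 2 values shown sit). Compound 3 `COCOCCOc1cc(OC)ccc1C[S+]([O-])c1ncccc1C(=O)Nc1ccncc1` differs from compound 1 by methoxymethoxy in place of fluoro on a saturated chain carbon, two bonds along the chain from an oxygen on an aromatic ring with methoxymethoxy in place of fluoro on a saturated chain carbon, two bonds along the chain from an oxygen on an aromatic ring. Among the compounds with values here, no measured step tests this change, so none beyond the scatter is expected in this assay for it. The estimated change is a step that the limit leaves unreadable from compound 1 to compound 3 in size. For compound 3 the estimated half-life is 0.015 h with an expected range (0.008 h to 0.03 h).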

Compound 3, half-life: < 0.02 h
Compound 3 ended at the assay's limit; the forecaster's own chance of this, stated with the estimate: 85%; the middle value lies beyond the limit too.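

No step can be read from compound 1 to compound 3, as both sit at a limit of the assay and not at a number: the limit of < 0.02 h in this assay, at which 3 of the 3 values shown sit. The compounds shown leave open how methoxymethoxy and fluoro compare in this assay.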